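The source may hold more compounds than are shown below. What is called first, only, known or untested is meant among the compounds shown, and "the series" means these compounds.

Measured compounds:
- compound 1, `COc1ccc(N/C=C\C(=O)c2cn(-c3ccccc3)nc2-c2ccc(Cl)cc2)cc1`: 8930 nM
- compound 2, `COc1cc(-c2nn(-c3ccccc3)cc2C(=O)/C=C\Nc2ccc(Cl)cc2)cc(OC)c1OC`: 7680 nM
- compound 3, `COc1cc(-c2nn(-c3ccccc3)cc2C(=O)/C=C\Nc2ccc(O)cc2)cc(OC)c1OC`: 2500 nM

All three were tested in a functional assay on HT-29 cells (Homo sapiens) for antiproliferative activity, read by MTT assay, with a stated time of 48 h; a lower number here means a stronger inhibitor, a higher number a weaker inhibitor. Compound 3 gives the lowest number of the three, and the other two stand clearly apart from it: compound 2 sits a modest step higher, and compound 1 a little further up again. Among the measured compounds shown here, the one step that can be read directly, a 3.1-fold lower number from compound 2 to compound 3 (0.49 log units; beyond the scatter), shows that swapping a chloro for a hydroxy on the anilino ring brings the number down.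

Compound 4, `COc1ccc(N/C=C\C(=O)c2cn(-c3ccccc3)nc2-c2cc(OC)c(OC)c(OC)c2)cc1`, has not yet been measured. It differs from compound 3 only by methyl in place of hydrogen on an oxygen on an aromatic ring, so the hydroxy of compound 3 becomes a methoxy. For the measured compounds named here, no measured pair isolates this exact change. Compound 1 carries the same methoxy on its anilino ring, but it also differs from compound 2 in the other aryl group, so its value and that of compound 2 can only be compared as numbers: they lie close together, within the usual scatter. That hints that a methoxy on this ring behaves more like the chloro of compound 2 than like the hydroxy of compound 3. Compound 4 is therefore expected to give a higher number than compound 3, by about a 2.4-fold higher number from compound 3 to compound 4 (0.38 log units; beyond the scatter), though the evidence is thin. The estimate for compound 4 in this assay is 6000 nM, with a plausible range from 2500 nM to 14000 nM.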

Compound 4, half-maximal inhibitory concentration: 5780 nM
For compound 4 the middle estimate is 1.0-fold (0.02 log units) above the measured one; measured number inside the range.
By their numbers in this assay, from the lowest: compound 3; then compounds 4, 2 and 1 (each within the scatter of the next).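

In this assay, adding a methyl to the oxygen of compound 3 gives a 2.3-fold higher number from compound 3 to compound 4 (0.36 log units; beyond the scatter) as its result, so at this position the lower number goes with the free hydroxy, not with just any oxygen on the ring. Methoxy and chloro on this ring cannot be told apart here, as a 1.3-fold lower number from compound 2 to compound 4 (0.12 log units; within the scatter) shows for this pair. Changing the other aryl group also separates nothing, with a 1.5-fold lower number from compound 1 to compound 4 (0.19 log units; within the scatter) for 3,4,5-trimethoxyphenyl in place of 4-chlorophenyl.

Nothing measured here explains why the hydroxy stands apart from the methoxy. From the compounds shown here alone, it also stays open whether an amine or a carboxylic acid in this place would go with a number like that of the hydroxy or like that of the methoxy.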